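Chloro on the enone aryl ring and PC-3 inhibition

A few compounds are considered here, and "the series" means these few. Any claim that something is new, unique, unknown or untested is made for them only; others in the source may bear on it.

Values obtained so far in a functional assay on PC-3 cells (Homo sapiens) for inhibition, read by MTT assay, with a stated time of 48 h; a higher number here means a weaker inhibitor, a lower number a stronger inhibitor:

compound 1 `O=C(/C=C/c1ccccc1)c1ccc[nH]1`: > 100000 nM
compound 2 `O=C(/C=C/c1ccc(Cl)cc1)c1ccc[nH]1`: 18000 nM
compound 3 `O=C(/C=C/c1cccc([N+](=O)[O-])c1)c1ccco1`: 14000 nM

Compound 1 sits at the limit of > 100000 nM in this assay, at which 1 of the 3 values shown sits; its value is a limit of the assay and not a number. Compound 2 differs from compound 1 by one change, (chloro in place of hydrogen on an aromatic carbon), and this change gave an at least 5.5-fold lower number from compound 1 to compound 2 (0.74 log units; beyond the scatter). Compound 3 carries a different core; the difference between the two cores is not broken down here. In this assay compound 3 and compound 2 lie within the usual scatter of each other, so no order between them is read.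

Compound 4 `O=C(/C=C/c1cc([N+](=O)[O-])ccc1Cl)c1ccco1` has not yet been measured. It differs from compound 3 by chloro in place of hydrogen on an aromatic carbon. This is the same kind of change as from compound 1 to compound 2, not the same one: in compound 2 the chloro sits para to a group of 9 heavy atoms, whereas in compound 4 it sits ortho to a group of 9 heavy atoms and para to a nitro group, on a ring that also carries that nitro group. The step is therefore expected to be smaller than an at least 5.5-fold lower number from compound 1 to compound 2 (0.74 log units; beyond the scatter), which started from a limit, and the expected step from compound 3 to compound 4 is a 2.3-fold lower number from compound 3 to compound 4 (0.37 log units; beyond the scatter). Compound 4 is estimated at 6000 nM, with the expected range running from 2000 nM to 20000 nM.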

Compound 4, half-maximal inhibitory concentration: 62000 nM
Compound 4: middle estimate off by 10-fold (1.01 log units), on the low side; the whole stated range lies below it.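

In this assay the same replacement of hydrogen by chloro gives a 4.4-fold higher number from compound 3 to compound 4 (0.65 log units; beyond the scatter), so the direction of the change does not carry from one core to the other among these compounds: the same change on two cores in this assay, an at least 5.5-fold lower number (0.74 log units; beyond the scatter) from compound 1 to compound 2 and a 4.4-fold higher number (0.65 log units; beyond the scatter) from compound 3 to compound 4, at least 24-fold (1.39 log units) apart, beyond the scatter of two such steps

The earlier step starts from a limit, so only a bound on its size is available: the limit of > 100000 nM in this assay, at which 1 of the 4 values shown sits.

Two steps cannot separate the core, the nitro group and the place of the chloro, which in compound 4 is ortho to a group of 9 heavy atoms and para to a nitro group, so they show no rule for chloro across the series and do not identify which of these differences sets the outcome.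

Open, on these data alone, is whether chloro on the core of compound 3 gives a higher number in this assay without the nitro group on the ring, and whether it does so at another place on that ring. Also open, as far as these compounds go, is how an amine, a carboxylic acid or a longer chain in the place of the chloro in compound 4 would read in this assay.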